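The source may hold more compounds than are shown below. What is called first, only, known or untested is meant among the compounds shown, and "the series" means these compounds.

Measured compounds:
compound 1 `CCC(C)(C)Cc1c[nH]c(CCc2ccc(-c3cccc(C)n3)cc2)n1` with 19 nM
compound 2 `CCC(C)(C)Cc1c[nH]c(CCc2ccc(-c3cccc(N)n3)cc2)n1` with 3.9 nM

Both were tested in a functional assay on HEK293 cells for agonist activity at Bombesin receptor subtype-3 (Mus musculus), read by luminescence and calcium flux, with a stated time of 10 min; a lower number here means that less compound is needed, a higher number that more compound is needed for the effect. Within the data shown here, compound 2 gives the lowest of the two numbers in this assay, and its nearest neighbour is compound 1, whose number is higher; the one measured step, a 4.9-fold lower number from compound 1 to compound 2 (0.69 log units; beyond the scatter), is the only guide available.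

Compound 3 `CCC(C)(C)Cc1c[nH]c(CCc2ccc(N3CCCCC3)cc2)n1` has not yet been measured. It differs from compound 2 in one place: piperidin-1-yl in place of 6-aminopyridin-2-yl on an aromatic carbon. The step from compound 1 to compound 2 bears on this only partly, since it shows what the amino group on the pyridinyl ring contributes, and compound 3 gives up both that amino group and the aromatic ring itself. Nothing measured shows a saturated ring at this position. Compound 3 is therefore expected to return a higher number than compound 2, with a step of about a 10-fold higher number from compound 2 to compound 3 (1.01 log units; beyond the scatter), and the estimate for compound 3 is 40 nM, within a range from 8 nM to 200 nM.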

Compound 3, half-maximal effective concentration: 28 nM
Compound 3: the middle estimate sits 1.4-fold (0.15 log units) above what was measured; the range from low to high includes it.
By their numbers in this assay, from the lowest: compound 2; then compounds 1 and 3 (each within the scatter of the next).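

In this assay, among these compounds, piperidin-1-yl is the first non-aromatic ring seen on this aromatic carbon, and the loss of 6-aminopyridin-2-yl gives a 7.2-fold higher number from compound 2 to compound 3 (0.86 log units; beyond the scatter) beyond what compound 2 showed on its own. Exchanging 6-methylpyridin-2-yl for the same saturated ring gives a 1.5-fold higher number from compound 1 to compound 3 (0.17 log units; within the scatter) and so does not separate compound 1 from compound 3, which shows that among these three compounds only the one with 6-aminopyridin-2-yl stands apart, while an aromatic ring at this position is not needed to reach the level of compound 1. No evidence is available that explains these numbers.

Still open, from the compounds shown here alone, is whether an amino group placed on the saturated ring would lower the number, as it did on the pyridinyl ring. Equally open, going by these compounds, is whether a morpholin-4-yl or pyrrolidin-1-yl ring would behave like piperidin-1-yl.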